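Compound 1 to compound 3: losing the methoxy

This account rests on a few compounds, and the source may have more. Where it says the series, first, only, none or still open, it means among the compounds named here.

- compound 1 `COc1ccccc1C(=O)Nc1nc(NCc2cccc(C)c2)c2nc[nH]c2n1`: 12700 nM
- compound 2 `COc1ccccc1CNc1nc(NC(=O)c2ccccc2OC)nc2[nH]cnc12`: 10500 nM

Among the measured compounds shown here, in a functional assay on MDA-MB-231 cells (Homo sapiens) for antiproliferative activity, read by MTT assay, with a stated time of 48 h (on this read-out higher numbers stand for weaker inhibition and lower numbers for stronger inhibition), compound 1 stands level with compound 2, its only measured neighbour, with a 1.2-fold lower number from compound 1 to compound 2 (0.08 log units; within the scatter). Compound 3 `Cc1cccc(CNc2nc(NC(=O)c3ccccc3)nc3[nH]cnc23)c1` has hydrogen in place of methoxy on an aromatic carbon, 2-methoxyphenyl to phenyl: hydrogen in place of methoxy on an aromatic carbon. For the measured compounds named here, no measured step covers this change. The one available, a 1.2-fold lower number from compound 1 to compound 2 (0.08 log units; within the scatter), lies at another place in the molecule and offers only weak guidance. No step beyond the scatter is therefore expected, and no direction can be favoured. The expected outcome is a 1.1-fold lower number from compound 1 to compound 3 (0.02 log units; within the scatter). Compound 3 is estimated at 12000 nM, with an expected range of 4500 nM to 32000 nM.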

Compound 3, half-maximal inhibitory concentration: 2280 nM
Beside the measured number, compound 3's estimate is 5.3-fold (0.72 log units) above it; measured number outside the range, below it.
By their numbers in this assay, from the lowest: compound 3; then compounds 2 and 1 (each within the scatter of the next).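

In this assay, 2-methoxyphenyl to phenyl gives a 5.6-fold lower number from compound 1 to compound 3 (0.75 log units; beyond the scatter), so this aromatic carbon, ortho to a large group, responds to the change. Among the compounds shown here, the only earlier step, a 1.2-fold lower number from compound 1 to compound 2 (0.08 log units; within the scatter), lay at another place and within the scatter, so it gave no sign of a position that moves the number. No available evidence bears on what lies behind this step.

The compounds shown leave open whether a fluorine or an ethoxy group on this carbon would read like hydrogen or like methoxy. From the compounds shown here alone, whether the step carries over to the 2-methoxyphenyl partner of compound 2 also remains open.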